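The compounds below may be only part of what the source reports. "The series", "measured", "known", "first", "only" and "open" are said of these compounds alone.

Working notes on the series. Of the compounds shown here, three have been measured so far: compound 1 `CC(C)(C)Cc1csc(N)c1C(=O)c1cccc(Cl)c1`, compound 2 `CC(C)(C)Cc1c(-c2ccc(F)cc2F)sc(N)c1C(=O)c1ccc(Cl)cc1` and compound 3 `Cc1ccc(C(=O)c2c(N)sc(-c3ccccc3)c2CC(C)(C)C)cc1`. In an assay on CHO cells for displacement of a labelled ligand from adenosine receptor A1 (Homo sapiens), read by scintillation counting, tested at 10 uM (a higher number here means more inhibition at the concentration tested (going by the name of the read-out), a lower number less inhibition), compound 1 gives 2%, compound 2 gives 1% and compound 3 gives 1%. Compound 2 reads level with compound 3 at the digits reported, the two together the lowest of the three numbers, and the gap to compound 1 lies within the scatter, so no ordering among them is claimed.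

The next compound, compound 4 `Cc1noc(C)c1-c1sc(N)c(C(=O)c2ccc(Cl)cc2)c1CC(C)(C)C`, differs from compound 2 in one place: 3,5-dimethyl-1,2-oxazol-4-yl in place of 2,4-difluorophenyl on an aromatic carbon. Within the data shown here, no step between measured compounds is at hand, so this change has no precedent in this assay. Given that compound 2 gives 1%, compound 4 is expected to give 2%, in the range 0% to 12%. The expected step of a number 1 percentage points higher from compound 2 to compound 4 (within the scatter) is none beyond the scatter.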

Compound 4, a percentage reported as inhibition, at one concentration (the size of the read-out at that concentration, not a potency): 1%
Estimate against measurement, compound 4: 1 percentage points above; low and high end bracket the measured number.
By their numbers in this assay, from the lowest: compounds 2, 3, 4 and 1 (each within the scatter of the next).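

In this assay, 3,5-dimethyl-1,2-oxazol-4-yl in place of 2,4-difluorophenyl next to the ring sulfur gives no change at the digits printed from compound 2 to compound 4 (within the scatter). At this position, then, a five-membered aromatic ring with 2 hetero atoms and 2 hydrogen-bond acceptors reads the same as a six-membered aromatic ring of carbon only with 0 acceptors. No available measurement accounts for this result. Open, as far as these compounds go, is whether a basic amine such as morpholine or a carboxylic acid at this position would read any differently from compound 2. Also open, from the compounds shown here alone, is whether the same change would read alike on a different neopentyl or benzoyl substitution pattern.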